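The source may hold more compounds than are shown below. What is called first, only, known or untested is meant among the compounds shown, and "the series" means these compounds.

Measured compounds:
- compound 1 `CCOC(=O)c1cc(=O)c2cc(CSC(=S)N(C(C)C)C(C)C)ccc2o1`, in a functional assay on HEp-2 cells (Homo sapiens) for antiproliferative activity, read by MTT assay, with a stated time of 72 h (a lower number here means a stronger inhibitor, a higher number a weaker inhibitor), compound 1 gives 15900 nM
- compound 2 `O=c1c(CSC(=S)N2CCCC2)coc2ccccc12`, in this assay compound 2 gives 3600 nM
- compound 3 `CC(C)N(C(=S)SCc1coc2ccccc2c1=O)C(C)C`, in this assay compound 3 gives 3000 nM

Compound 1 stands apart from the other two, its number lying beyond the scatter from both. Compound 3 and compound 2 share a core and differ by one change, (pyrrolidin-1-yl in place of diisopropylamino on a thiocarbonyl carbon), which gave a 1.2-fold higher number from compound 3 to compound 2 (0.08 log units; within the scatter).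

Compound 4 `CCOC(=O)c1cc(=O)c2cc(CSC(=S)N3CCCC3)ccc2o1` is unmeasured. It carries the same change on the core of compound 1: pyrrolidin-1-yl in place of diisopropylamino on a thiocarbonyl carbon. The difference between the two cores is not broken down here. Because the same exchange gave a 1.2-fold higher number from compound 3 to compound 2 (0.08 log units; within the scatter), little movement is expected from compound 1 to compound 4, and the expected step is a 1.1-fold higher number from compound 1 to compound 4 (0.05 log units; within the scatter). The uncertainty is wider than for the measured pair, since the cores differ. In this assay compound 4 is estimated at 18000 nM, between 7000 nM and 45000 nM.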

Compound 4, half-maximal inhibitory concentration: 8900 nM
Beside the measured number, compound 4's estimate is 2.0-fold (0.31 log units) above it; measured number inside the range.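

In this assay, pyrrolidin-1-yl in place of diisopropylamino on a thiocarbonyl carbon gave a 1.8-fold lower number from compound 1 to compound 4 (0.25 log units; within the scatter), so on the core of compound 1 this exchange also stays within the scatter. The two steps do not differ beyond what is expected of such a pair: the same change on two cores in this assay, a 1.2-fold higher number (0.08 log units; within the scatter) from compound 3 to compound 2 and a 1.8-fold lower number (0.25 log units; within the scatter) from compound 1 to compound 4, 2.1-fold (0.33 log units) apart, within the scatter of two such steps. This supports carrying the exchange between these two cores with little movement expected, but it rests on two pairs only, does not extend to other cores and does not break down the difference between the two cores.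

The compounds shown leave open how piperidine, morpholine or diethylamino would behave on the thiocarbonyl carbon. They also leave open whether a carboxylic acid in place of the ethyl ester would alter the number.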